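A Second Trifluoromethyl Group on Two Related Anilide Cores

The compounds below may be only part of what the source reports. "The series", "measured", "known", "first", "only" and "open" are said of these compounds alone.

Four thioether anilides are compared in a functional assay on CWR22R cells (Homo sapiens) for antiproliferative activity, read by propidium iodide staining, with a stated time of 96 h; a lower number here means a stronger inhibitor, a higher number a weaker inhibitor. Compound 1 has the structure `CC(O)(CSc1cccc(C(F)(F)F)c1)C(=O)Nc1ccc(S(F)(F)(F)(F)F)cc1`, and in this assay compound 1 gives 23400 nM. Compound 2, `CC(O)(CSc1cc(C(F)(F)F)cc(C(F)(F)F)c1)C(=O)Nc1ccc(S(F)(F)(F)(F)F)cc1`, differs from compound 1 by trifluoromethyl in place of hydrogen on an aromatic carbon, and compound 2 gives 15800 nM. This change produced a 1.5-fold lower number from compound 1 to compound 2 (0.17 log units; within the scatter).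

Compound 3, `CC(O)(CSc1cccc(C(F)(F)F)c1)C(=O)Nc1cccc(S(F)(F)(F)(F)F)c1`, has the same atoms as compound 1 joined differently; the difference between the two cores is not broken down here. In this assay compound 3 gives 12900 nM. Its number stands close to those of compound 2 and compound 1, and the gaps between all three fall within the usual scatter of repeated measurements, so no order among them can be read from these data.

Compound 4, `CC(O)(CSc1cc(C(F)(F)F)cc(C(F)(F)F)c1)C(=O)Nc1cccc(S(F)(F)(F)(F)F)c1`, has not yet been measured. It differs from compound 3 by trifluoromethyl in place of hydrogen on an aromatic carbon, which is the same change as that from compound 1 to compound 2, made on the core of compound 3 instead. Among the measured compounds shown here, because the earlier step gave a 1.5-fold lower number from compound 1 to compound 2 (0.17 log units; within the scatter), a step of similar size is expected here, namely a 1.5-fold lower number from compound 3 to compound 4 (0.18 log units; within the scatter), resting on the single measured pair alone. The value of compound 4 in this assay is therefore estimated at 8600 nM, with the likely range running from 4000 nM to 18000 nM.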

Compound 4, half-maximal inhibitory concentration: 4400 nM
The estimate for compound 4 lay 2.0-fold (0.29 log units) above the measured number; low and high end bracket the measured number.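

Read in this assay, the added trifluoromethyl group gives a 2.9-fold lower number from compound 3 to compound 4 (0.47 log units; beyond the scatter), and this is the only one of the two measured steps for this change that stands clear of the usual scatter. Set beside the earlier step, the size of the change on the two cores cannot be told apart, so the two results fit a single step of similar size carried from one core to the other: the same change on two cores in this assay, a 1.5-fold lower number (0.17 log units; within the scatter) from compound 1 to compound 2 and a 2.9-fold lower number (0.47 log units; beyond the scatter) from compound 3 to compound 4, 2.0-fold (0.30 log units) apart, within the scatter of two such steps This does not show that the core of compound 3 responds more strongly than the core of compound 1, and with only two pairs it fixes no size for the step that could be relied on for any further core.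

The compounds shown leave open whether a chlorine atom, a nitrile or a methoxy group on the same aromatic carbon would give a step like that of trifluoromethyl. They also leave open how the numbers would move if the sulfur of the thioether link became a sulfonyl group, or if the hydroxyl group gave way to an amine.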